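Fluoro Added on an Aromatic Carbon of Compound 3

The compounds below may be only part of what the source reports. "The series", "measured", "known", "first", "only" and "open" are said of these compounds alone.

The three measured compounds, all read in a functional assay on A549 cells (Homo sapiens) for antiproliferative activity, read by MTT assay, with a stated time of 72 h; on this read-out lower numbers stand for stronger inhibition and higher numbers for weaker inhibition:
compound 1 `C=CC(=O)Nc1cc(Nc2nc(C)cc(-c3cn(C)c4ccccc34)n2)c(OC)cc1N(C)CCN(C)C` gives 2910 nM
compound 2 `COc1cc(N(C)CCN(C)C)c(NC(=O)/C=C\C(C)C)cc1Nc1nc(C)cc(-c2cn(C)c3ccccc23)n1` gives 1070 nM
compound 3 `CCC/C=C\C(=O)Nc1cc(Nc2nc(C)cc(-c3cn(C)c4ccccc34)n2)c(OC)cc1N(C)CCN(C)C` gives 329 nM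

All three share one core and differ only in the chain attached to the carbonyl carbon of the amide. Compound 3 stands at the lowest number of the three, which on this read-out means the strongest inhibition, and both of its steps lie beyond the scatter: an 8.8-fold lower number from compound 1 to compound 3 (0.95 log units; beyond the scatter) and a 3.3-fold lower number from compound 2 to compound 3 (0.51 log units; beyond the scatter). The remaining step, a 2.7-fold lower number from compound 1 to compound 2 (0.43 log units; beyond the scatter), is also beyond the scatter.

Compound 4 `CCC/C=C\C(=O)Nc1cc(Nc2nc(C)cc(-c3cn(C)c4ccc(F)cc34)n2)c(OC)cc1N(C)CCN(C)C` keeps the pent-1-en-1-yl chain of compound 3 and changes a different part of the molecule: fluoro in place of hydrogen on an aromatic carbon. Within the data shown here, none of the measured steps touches this position; each of them altered the chain on the carbonyl carbon, so they give no direct guide to what a fluoro on the aromatic ring will do. With nothing in the data pointing either way, the expected change is small. Compound 4 is estimated at 300 nM, with a range from 100 nM to 900 nM, corresponding to an expected step of a 1.1-fold lower number from compound 3 to compound 4 (0.04 log units; within the scatter).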

Compound 4, half-maximal inhibitory concentration: 13300 nM
The estimate for compound 4 lay 44-fold (1.65 log units) below the measured number, outside the stated range (above it).
By their numbers in this assay, from the lowest: compound 3; then compound 2; then compound 1; then compound 4.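

Going from 1-methyl-1H-indol-3-yl to 5-fluoro-1-methyl-1H-indol-3-yl adds a single heavy atom, yet in this assay it gives a 40-fold higher number from compound 3 to compound 4 (1.61 log units; beyond the scatter), a larger move than any step among the chains on the carbonyl carbon. Among these compounds, this shows that the aromatic carbon carrying the fluoro, a position none of the earlier steps touched, is far from a silent spot on the molecule: with the pent-1-en-1-yl chain in place, this one replacement of hydrogen takes away most of the inhibition seen with compound 3. Nothing available here explains why the number rises so sharply.

A single group at a single carbon cannot show whether the loss belongs to fluoro itself or to any replacement of hydrogen there, so a chloro, methyl or methoxy group on the same carbon would be the natural comparison. On these data alone, it also remains open whether fluoro at this carbon has the same effect alongside the vinyl chain of compound 1 or the 3-methylbut-1-en-1-yl chain of compound 2, or at the other aromatic carbons of the same ring.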